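Removing One Trifluoromethyl From an Inactive Urea

The source may report more compounds than this note shows. Statements on the series, on what has been measured and on what is new or still open speak of the compounds shown alone.

Compound 1 `COc1cc(-c2nn(-c3cccc(NC(=O)Nc4cc(C(F)(F)F)cc(C(F)(F)F)c4)c3)cc2-c2ccncc2)ccc1Cl` was tested in a functional assay on PC-3 cells (Homo sapiens) for inhibition, read by sulforhodamine B assay, with a stated time of 48 h; on this read-out lower numbers stand for higher toxicity in this test and higher numbers for lower toxicity in this test. In this assay compound 1 reached only the limit > 50000 nM, so no number is known for it. Compound 2 `O=C(Nc1cccc(-n2cc(-c3ccncc3)c(-c3ccc(Cl)c(O)c3)n2)c1)Nc1ccc(Cl)c(Cl)c1` also sits at a limit, > 32500 nM, in this assay. Both values shown are therefore limits, and compound 1 is one of them. Compound 3 `COc1cc(-c2nn(-c3cccc(NC(=O)Nc4cccc(C(F)(F)F)c4)c3)cc2-c2ccncc2)ccc1Cl` differs from compound 1 by hydrogen in place of trifluoromethyl on an aromatic carbon. With both measured compounds at limits, no change beyond the scatter is expected, and a number no higher from compound 1 to compound 3 (the limit leaves the size open) is the estimated step. Compound 3 is expected to give about 50000 nM in this assay, between 20000 nM and 120000 nM, probably again only as a limit.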

Compound 3, concentration lethal to 50% of the cells: > 50000 nM
Compound 3: only a limit was reported; the forecaster's own chance of this, stated with the estimate: 80%; the middle value sits exactly at the limit.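

Compound 1 and compound 3 are both reported only as limits, so no step can be read between them. The compounds shown leave open what either true value is, and whether swapping trifluoromethyl for hydrogen changes it.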